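The source may hold more compounds than are shown below. What is called first, only, known or untested is meant among the compounds shown, and "the series" means these compounds.

In a functional assay on aorta (Rattus norvegicus, strain Wistar) for inhibition, with a stated time of 60 min (on this read-out higher numbers stand for larger maximal responses and lower numbers for smaller maximal responses), compound 2 `FC(F)(F)c1ccc2[nH]c(-c3ccccc3)nc2c1` gives 91.2%. Compound 1 `CCCOc1ccc(-c2nc3cc(C(F)(F)F)ccc3[nH]2)cc1` gives 51%, and compound 3 `Oc1ccc(-c2nc3cc(C(F)(F)F)ccc3[nH]2)cc1` gives 51.2%. Compound 3 thus stands second highest of the three, within the scatter of compound 1 and far beneath compound 2. Compound 4 `CN(C)c1ccc(-c2nc3cc(C(F)(F)F)ccc3[nH]2)cc1` differs from compound 3 by dimethylamino in place of hydroxy on an aromatic carbon. Among the measured compounds shown here, the steps that bear on this change are a number 40 percentage points lower from compound 2 to compound 3 (beyond the scatter) and a number 40.2 percentage points higher from compound 1 to compound 2 (beyond the scatter), whereas a number 0.2 percentage points higher from compound 1 to compound 3 (within the scatter). Both groups measured at this place gave similar maximal responses, so a third group there is expected to behave alike, with no step beyond the scatter. For compound 4 the expected step is a number 0.8 percentage points higher from compound 3 to compound 4 (within the scatter). Compound 4 is therefore estimated at 52%, within the range 35% to 70%.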

Compound 4, largest response reached (Emax), in percent of the reference or control that the assay uses: 63.2%
The estimate for compound 4 lay 11.2 percentage points below the measured number; low and high end bracket the measured number.
By their numbers in this assay, from the lowest: compounds 1 and 3 (each within the scatter of the next); then compound 4; then compound 2.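

Dimethylamino does not behave like hydroxy and propoxy at this place on the ring: the data show a number 12 percentage points higher from compound 3 to compound 4 (beyond the scatter) and a number 12.2 percentage points higher from compound 1 to compound 4 (beyond the scatter). It still falls short of plain hydrogen, with a number 28 percentage points lower from compound 2 to compound 4 (beyond the scatter), so the three groups at this place do not all lower the maximal response by one shared amount. No measurement at hand explains this difference. On these data alone, whether a primary amine or a carboxylic acid here would land nearer hydrogen or nearer hydroxy remains open, as does whether the nitrogen or its two methyl groups set the dimethylamino result.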